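Side chain branching from compound 2 to compound 3

A few compounds are considered here, and "the series" means these few. Any claim that something is new, unique, unknown or untested is made for them only; others in the source may bear on it.

Measured so far in a functional assay on NCI-H460 cells (Homo sapiens) for antiproliferative activity, read by MTT assay, with a stated time of 72 h; on this read-out higher numbers stand for weaker inhibition and lower numbers for stronger inhibition
compound 1 `COc1cc2c(Oc3ccc(Nc4nccc5[nH]cc(-c6ccc(F)cc6)c(=O)c45)cc3F)ccnc2cc1OCCO` gives 2000 nM
compound 2 `O=c1c(-c2ccc(F)cc2)c[nH]c2ccnc(Nc3ccc(Oc4ccnc5cc(OCCO)ccc45)c(F)c3)c12` gives 3500 nM

In this assay, among the measured compounds shown here, compound 2 gives 3500 nM and the one other value, from compound 1, lies within the scatter of it, so the two are not separated. Compound 3 `CC(C)(O)COc1ccc2c(Oc3ccc(Nc4nccc5[nH]cc(-c6ccc(F)cc6)c(=O)c45)cc3F)ccnc2c1` is still unmeasured and differs from compound 2 in the side chain. The change is 1-hydroxy-1-methylethyl in place of hydroxymethyl on a saturated chain carbon bound to an oxygen on an aromatic ring and reads, cut one bond further out, 2-hydroxyethoxy to 2-hydroxy-2-methylpropoxy. For the measured compounds named here, no measured pair tests this change. Going by the values given here, the only measured step is a 1.8-fold higher number from compound 1 to compound 2 (0.24 log units; within the scatter) and it concerns hydrogen in place of methoxy on an aromatic carbon, not the side chain. That step lies within the scatter and gives neither a size nor a direction for the new group. No step beyond the scatter is therefore expected in this assay for this change. The expected step is a 1.2-fold lower number from compound 2 to compound 3 (0.07 log units; within the scatter) and it is not expected to leave the scatter. For compound 3 the estimate is 3000 nM with an expected range of 1200 nM to 8000 nM in this read-out.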

Compound 3, half-maximal inhibitory concentration: 3200 nM
Estimate against measurement, compound 3: 1.1-fold (0.03 log units) below, and the stated range covers the measured number.
By their numbers in this assay, from the lowest: compounds 1, 3 and 2 (each within the scatter of the next).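

In this assay the side chain now has its first measured step: 2-hydroxyethoxy to 2-hydroxy-2-methylpropoxy gives a 1.1-fold lower number from compound 2 to compound 3 (0.04 log units; within the scatter) and so does not separate the two compounds. The earlier pair addressed only hydrogen in place of methoxy on an aromatic carbon, whereas this pair shows that 1-hydroxy-1-methylethyl, with 4 heavy atoms, can take the place of hydroxymethyl, with 2, on a saturated chain carbon bound to an oxygen on an aromatic ring without a step beyond the scatter. No supporting data are available to interpret this result, so it stands as a plain observation on one pair.

As far as these compounds go, both groups compared here carry a hydroxy group, so it remains open whether an amine, a carboxylic acid or a longer chain in place of 1-hydroxy-1-methylethyl would give a step beyond the scatter in this assay. Also open, from the compounds shown here alone, is whether the change from 2-hydroxyethoxy to 2-hydroxy-2-methylpropoxy would read the same on the methoxy-bearing core of compound 1.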